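This account rests on a few compounds, and the source may have more. Where it says the series, first, only, none or still open, it means among the compounds named here.

Working notes on the series.

Two compounds of the shared core carry a measurement so far. Compound 1 `CCCCc1ccc(-c2c(C)[nH]c(=O)n2C(C)C)cc1` and compound 2 `CCCc1ccc(-c2c(C)[nH]c(=O)n2C)cc1` were both tested in a functional assay on brain (Rattus norvegicus, strain Wistar) for inhibition; a lower number here means a stronger inhibitor, a higher number a weaker inhibitor. In this assay compound 1 gives 10700 nM. In this assay compound 2 gives 21500 nM. Compound 2 thus stands at one end of the two numbers shown, but its gap to compound 1 lies within the usual scatter of repeated measurements, so the two numbers do not separate the compounds; compound 1 and compound 2 also differ in two places at once, so no single step can be read from them.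

The next compound, compound 3 `CCCCCCCc1ccc(-c2c(C)[nH]c(=O)n2C)cc1`, is not yet measured. Relative to compound 2 the change is butyl in place of hydrogen on a saturated chain carbon, three bonds along the chain from an aromatic carbon. Among the measured compounds shown here, no measured pair in this set isolates a change of this kind, so the size of the step is open. The expectation is a moderate step toward a lower number, beyond the scatter, from compound 2 to compound 3 of about a 4.3-fold lower number from compound 2 to compound 3 (0.63 log units; beyond the scatter). On that basis compound 3 is estimated at 5000 nM in this assay, with a range from 1500 nM to 16000 nM.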

Compound 3, half-maximal inhibitory concentration: 8400 nM
Compound 3: middle estimate off by 1.7-fold (0.23 log units), on the low side; low and high end bracket the measured number.
By their numbers in this assay, from the lowest: compounds 3, 1 and 2 (each within the scatter of the next, the first and the last beyond it).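

Among the compounds shown here, compound 3 supplies the first step that can be read at a single place: in this assay, butyl in place of hydrogen on a saturated chain carbon, three bonds along the chain from an aromatic carbon, gives a 2.6-fold lower number from compound 2 to compound 3 (0.41 log units; beyond the scatter) and so reads as propyl to heptyl on the shared core. This position therefore accepts the added butyl without a move toward a higher number, and the modest shift lies beyond the scatter, which the earlier pair of compounds could not show. Nothing measured here bears on why the number moves.

With only propyl and heptyl compared at this position on this background, the compounds shown leave open whether the number falls steadily with chain length, levels off or turns back, and a pentyl chain or a chain longer than heptyl would settle that. Also open, from the compounds shown here alone, is whether the position depends on a plain hydrocarbon chain at all, which a heptyl chain ending in an amine or a carboxylic acid would test.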